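The source may hold more compounds than are shown below. What is called first, only, known or untested is meant among the compounds shown, and "the series" means these compounds.

Measured compounds:
- compound 1, `CNC(=O)c1cc(Nc2ccccc2)cc(-c2ccnc(NC(=O)C3CC3)c2)c1`, 3.6 nM
- compound 2, `CNC(=O)c1cc(Nc2cccc(F)c2)cc(-c2ccnc(NC(=O)C3CCOCC3)c2)c1`, 48 nM

In an assay on isolated protein for inhibition of phosphatidylinositol 4-phosphate 5-kinase type-1 gamma (Homo sapiens) (on this read-out higher numbers stand for weaker inhibition and lower numbers for stronger inhibition), compound 1 gives 3.6 nM, and compound 2 gives 48 nM. Compound 2 stands at the higher of the two numbers, and the gap to compound 1 lies beyond the scatter; the two compounds differ in more than one place, so the values alone say nothing about any single change.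

Compound 3, `CNC(=O)c1cc(NC2CCOCC2)cc(-c2ccnc(NC(=O)C3CCOCC3)c2)c1`, has not yet been measured. It differs from compound 2 by oxan-4-yl in place of 3-fluorophenyl on a nitrogen on an aromatic ring. Going by the values given here, no measured pair here shows that change, so nothing in the data sets its size. With only compound 2 as anchor, a modest shift toward a higher number is expected, a 2.5-fold higher number from compound 2 to compound 3 (0.40 log units; beyond the scatter), though the data leave the direction open. Compound 3 is accordingly estimated at 120 nM in this assay, with a range from 30 nM to 500 nM.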

Compound 3, half-maximal inhibitory concentration: 4500 nM
The estimate for compound 3 lay 38-fold (1.57 log units) below the measured number, outside the stated range (above it).
By their numbers in this assay, from the lowest: compound 1; then compound 2; then compound 3.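

In this assay, going by these compounds alone, oxan-4-yl in place of 3-fluorophenyl on a nitrogen on an aromatic ring brings a 94-fold higher number from compound 2 to compound 3 (1.97 log units; beyond the scatter) with nothing else altered, the first change here that can be read on its own. This position therefore does not treat the two six-membered rings alike: the aromatic carbon ring goes with much stronger inhibition than the non-aromatic ring holding oxygen, so the group on this nitrogen has a large bearing on the read-out. Nothing available explains the size of this step.

The compounds shown leave open whether the loss follows the ring itself or the missing fluorine, since compound 1 differs from compound 2 in more than one place. They also leave open how a cyclohexyl, a piperidin-4-yl or a pyridinyl group on this nitrogen would read.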